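The compounds below may be only part of what the source reports. "The series", "measured", "known", "first", "only" and "open" are said of these compounds alone.

Measured compounds in the series:

Compound 1, `O=C(NCc1cc(C(F)(F)F)cc(C(F)(F)F)c1)C(c1ccccc1)c1ccccc1`, gives 526 nM in an assay on CHO cells for displacement of a labelled ligand from Substance-P receptor (Homo sapiens); a higher number here means a weaker inhibitor, a lower number a stronger inhibitor.
Compound 2, `CN(Cc1cc(C(F)(F)F)cc(C(F)(F)F)c1)C(=O)C(c1ccccc1)c1ccccc1`, gives 47 nM in this assay.
Compound 3, `COc1cc(CNC(=O)CC(c2ccccc2)c2ccccc2)cc(OC)c1`, gives 2240 nM in this assay.

Compound 1 and compound 2 share one core and differ by a single change, (methyl in place of hydrogen on an amide-type nitrogen). That change produced the step of an 11-fold lower number from compound 1 to compound 2 (1.05 log units; beyond the scatter), the one clear movement among the measured compounds. Compound 3 carries a different core; its difference from compound 1 is not broken down here. Of the three, compound 3 has the highest number, and its gap to compound 1 and to compound 2 lies beyond the scatter in each case.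

Compound 4, `COc1cc(CN(C)C(=O)CC(c2ccccc2)c2ccccc2)cc(OC)c1`, is not yet measured. It stands to compound 3 as compound 2 stands to compound 1: the change is methyl in place of hydrogen on an amide-type nitrogen, and the place is described in the same words for both pairs, so this is the same change made a second time on another core. Among the compounds with values here, only one prior example of the change exists, on a core that is not the core of compound 3, so how closely the result will carry over is uncertain.

The expected step from compound 3 to compound 4 in this assay is a 7.5-fold lower number from compound 3 to compound 4 (0.87 log units; beyond the scatter), resting on the step seen for compound 2 against compound 1, an 11-fold lower number from compound 1 to compound 2 (1.05 log units; beyond the scatter), with a somewhat smaller size allowed for the change of core. The estimated value for compound 4 in this assay is 300 nM, expected to fall between 100 nM and 900 nM.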

Compound 4, half-maximal inhibitory concentration: 226 nM
Compound 4: the middle estimate sits 1.3-fold (0.12 log units) above what was measured; measured number inside the range.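

In this assay, methyl in place of hydrogen on the amide-type nitrogen gives a 9.9-fold lower number from compound 3 to compound 4 (1.00 log units; beyond the scatter), and the size of this step matches the earlier one on the other core: the same change on two cores in this assay, an 11-fold lower number (1.05 log units; beyond the scatter) from compound 1 to compound 2 and a 9.9-fold lower number (1.00 log units; beyond the scatter) from compound 3 to compound 4, 1.1-fold (0.05 log units) apart, within the scatter of two such steps

Across the two cores shown, the change therefore carries over with no difference in size that can be told from the scatter, so the step seen on one core would have served as a fair guide to the step on the other. Within the data shown here, this rests on only two pairs, one per core, so it shows agreement between these two cores and not a general rule for the series, and it gives no explanation of why the methyl has this effect, as no property of the group has been measured.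

The compounds shown carry only hydrogen or methyl on that nitrogen, so it remains open whether an ethyl group, a longer chain or a chain ending in an amine would give a step of similar size. From the compounds shown here alone, it also remains open whether the methyl step would hold on a third core, or would hold in any read-out beyond this assay.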